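Amide aryl variation on the shared core: compound 3

A few compounds are considered here, and "the series" means these few. Any claim that something is new, unique, unknown or untested is made for them only; others in the source may bear on it.

Compound 1 `COc1ccc(NC(=O)c2cccc(/C=C3\CC(=O)N(c4ccccc4)C3=O)c2)c(C)c1` and compound 2 `O=C(Nc1ccc(F)cc1)c1cccc(/C=C2\CC(=O)N(c3ccccc3)C2=O)c1` share one core and differ only in the aryl group on the amide-type nitrogen. In an ADME assay on HCT-116 cells (Homo sapiens) for cytotoxicity, read by MTT assay, with a stated time of 72 h (a higher number here means a weaker inhibitor, a lower number a stronger inhibitor), compound 1 gives > 100000 nM, which is a limit of the assay and not a number. In this assay compound 2 gives > 100000 nM, again a limit. The step that the two limits leave unreadable from compound 1 to compound 2 therefore has no readable size; what is known is the limit of > 100000 nM in this assay, at which 2 of the 2 values shown sit. Going by the values given here, compound 2 thus stands at the limit, with no number beside it, as does the only other value shown.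

Compound 3 `CCOc1ccc(NC(=O)c2cccc(/C=C3\CC(=O)N(c4ccccc4)C3=O)c2)cc1` is the next member. It differs from compound 2 by ethoxy in place of fluoro on an aromatic carbon, on an aromatic carbon of a six-membered aromatic ring of carbon only, para to a large group. Among the compounds with values here, the only measured step, 4-fluorophenyl in place of 4-methoxy-2-methylphenyl on the amide-type nitrogen, touches the same aryl group but left no readable size, so no direction follows from it; the expectation rests on both measured values sitting at the limit. For compound 3 the expected step in this assay is a step that the limit leaves unreadable from compound 2 to compound 3, that is, none beyond the scatter. Compound 3 is estimated at 130000 nM, within 40000 nM to 400000 nM, with a strong chance that this assay again reports only a limit.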

Compound 3, half-maximal inhibitory concentration: 84800 nM
Estimate against measurement, compound 3: 1.5-fold (0.19 log units) above, within the range that was stated.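

Ethoxy in place of fluoro, on an aromatic carbon para to a large group, gives the first number of the series in this assay: compound 3 gives 84800 nM. The change reads as an at least 1.1-fold lower number from compound 2 to compound 3 (0.07 log units; that floor lies within the scatter), and the replacement of 4-methoxy-2-methylphenyl by 4-ethoxyphenyl reads as an at least 1.1-fold lower number from compound 1 to compound 3 (0.07 log units; that floor lies within the scatter); each of these is only a floor resting on a limit of the assay and not on a number, so neither step shows a separation beyond the scatter. A number is therefore reachable with this aryl group on the shared core, yet most of the series shown still stands at a limit: the limit of > 100000 nM in this assay, at which 2 of the 3 values shown sit.

On these data alone, the true size of either step beyond its floor stays open, and so does whether a real difference exists between compound 3 and the two compounds at the limit. Also open, as far as these compounds go, is how a propoxy chain, an amine or a carboxylic acid at this same aromatic carbon would read in this assay.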